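The compounds below may be only part of what the source reports. "The series", "measured", "known", "first", "only" and "open" are said of these compounds alone.

Compound 1 `COC(C)CO[C@H](CC=C(C)C)C1=CC(=O)c2c(O)ccc(O)c2C1=O`: 16600 nM
Compound 2 `CC(C)=CC[C@@H](OC(=O)C1CCCO1)C1=CC(=O)c2c(O)ccc(O)c2C1=O`: 10500 nM

In a functional assay on DU-145 cells (Homo sapiens) for cytotoxicity, read by MTT assay (on this read-out higher numbers stand for weaker inhibition and lower numbers for stronger inhibition), compound 2 gives 10500 nM, which is level with compound 1 once the usual scatter is allowed for. Compound 3 `CC(C)=CC[C@@H](OC(=O)C1CCCCO1)C1=CC(=O)c2c(O)ccc(O)c2C1=O` alters compound 2 in one place: oxan-2-yl in place of oxolan-2-yl on a carbonyl carbon, with oxan-2-yl in place of oxolan-2-yl on a carbonyl carbon. Among the measured compounds shown here, only one measured step bears on this, a 1.6-fold lower number from compound 1 to compound 2 (0.20 log units; within the scatter), and it replaced the whole group on that oxygen. With so little to go on, no clear change in either direction is expected. The expected step is a 1.0-fold higher number from compound 2 to compound 3 (0.02 log units; within the scatter). Compound 3 is expected at 11000 nM, with an estimated range of 5500 nM to 22000 nM.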

Compound 3, half-maximal inhibitory concentration: 24700 nM
Compound 3: middle estimate off by 2.2-fold (0.35 log units), on the low side, outside the stated range (above it).
By their numbers in this assay, from the lowest: compounds 2, 1 and 3 (each within the scatter of the next, the first and the last beyond it).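

Going from the five-membered to the six-membered ring on the carbonyl carbon gives the first change beyond the scatter in this assay, a 2.4-fold higher number from compound 2 to compound 3 (0.37 log units; beyond the scatter), so a single added ring carbon at this position can register in this read-out. Replacing the whole group on the oxygen, by contrast, gives a 1.5-fold higher number from compound 1 to compound 3 (0.17 log units; within the scatter), which leaves compound 3 level with compound 1. Nothing available here accounts for the difference between the two rings. Going by these compounds, it remains open whether oxetan-2-yl or an amine-bearing ring such as pyrrolidin-2-yl would follow compound 2 or compound 3.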